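A few compounds are considered here, and "the series" means these few. Any claim that something is new, unique, unknown or untested is made for them only; others in the source may bear on it.

Measured compounds:
- Compound 1, `O=C(OC1(C(=O)Nc2ccc([N+](=O)[O-])cc2)CCCCC1)c1ccc(Br)cc1`: 236 nM
- Compound 2, `O=C(OC1(C(=O)Nc2ccc([N+](=O)[O-])cc2)CCCCC1)C(O)c1ccccc1`: 7.8 nM

Compound 1 stands at the highest of the two numbers in a functional assay on NFS-60 cells (Mus musculus) for inhibition, read by MTT assay, with a stated time of 72 h; on this read-out higher numbers stand for weaker inhibition and lower numbers for stronger inhibition; its nearest neighbour is compound 2, reached by a 30-fold lower number from compound 1 to compound 2 (1.48 log units; beyond the scatter). Compound 3, `CC(=O)Oc1ccccc1C(=O)OC1(C(=O)Nc2ccc([N+](=O)[O-])cc2)CCCCC1`, has not yet been measured. It differs from compound 1 by 2-acetoxyphenyl in place of 4-bromophenyl on a carbonyl carbon. Among the compounds with values here, the one measured step exchanges the same 4-bromophenyl for hydroxy(phenyl)methyl and is large, but it does not share the change made here, where an aromatic ring stays in place and only its substituent changes. Within the data shown here, the data therefore offer no close precedent, and only a moderate movement from compound 1 is expected, most likely toward a lower number, as a 1.6-fold lower number from compound 1 to compound 3 (0.20 log units; within the scatter). Compound 3 is estimated at 150 nM in this assay, with a plausible range from 40 nM to 600 nM.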

Compound 3, half-maximal inhibitory concentration: 11.3 nM
For compound 3 the middle estimate is 13-fold (1.12 log units) above the measured one; measured number outside the range, below it.
By their numbers in this assay, from the lowest: compounds 2 and 3 (each within the scatter of the next); then compound 1.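

In this assay an aromatic ring can stay on the carbonyl carbon and the number can still fall a long way: putting 2-acetoxyphenyl in place of 4-bromophenyl gives a 21-fold lower number from compound 1 to compound 3 (1.32 log units; beyond the scatter) and so the earlier large step did not depend on moving the ring away from that carbon. The two replacements for 4-bromophenyl, although quite different groups, stay level, with a 1.4-fold higher number from compound 2 to compound 3 (0.16 log units; within the scatter) and neither can be ranked above the other. No measurement offered here explains why either exchange lowers the number.

Compound 3 differs from compound 1 in both losing the bromine and gaining the acetoxy group, so the compounds shown cannot say which of the two matters. From the compounds shown here alone, how a plain phenyl ring, or one carrying an amine or a carboxylic acid, would compare also remains open.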